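The source may report more compounds than this note shows. Statements on the series, on what has been measured and on what is new or still open speak of the compounds shown alone.

The series keeps one shared core, seen in compound 1 `CCNc1ccc(NC(=O)c2cc(Cl)ccc2O)c(Cl)c1`, and varies the group on the aryl amine nitrogen. In an ADME assay on A549 cells (Homo sapiens) for cytotoxicity, read by resazurin assay, with a stated time of 48 h (on this read-out higher numbers stand for lower toxicity in this test and lower numbers for higher toxicity in this test), compound 1 gives 30200 nM. Among the compounds with values here, compound 2 `O=C(Nc1ccc(NCc2cccc(C(F)(F)F)c2)cc1Cl)c1cc(Cl)ccc1O` carries 3-(trifluoromethyl)phenyl in place of methyl on a saturated chain carbon bound to a nitrogen on an aromatic ring; in this assay compound 2 gives 13300 nM, the lowest of the two numbers so far, and the step of a 2.3-fold lower number from compound 1 to compound 2 (0.36 log units; beyond the scatter) lies beyond the scatter. Compound 3 `O=C(Nc1ccc(NCc2cc(Cl)cc(C(F)(F)F)c2)cc1Cl)c1cc(Cl)ccc1O` differs from compound 2 by chloro in place of hydrogen on an aromatic carbon. Within the data shown here, only that one measured step bears on this change, and it involved a far larger exchange of groups than a single chloro, so only a small movement in this assay is expected, leaning toward a lower number. Compound 3 is therefore estimated at 9500 nM in this assay, within 4000 nM to 24000 nM. That estimate corresponds to an expected step of a 1.4-fold lower number from compound 2 to compound 3 (0.15 log units; within the scatter).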

Compound 3, half-maximal cytotoxic concentration: 30900 nM
Compound 3: middle estimate off by 3.3-fold (0.51 log units), on the low side; the whole stated range lies below it.
By their numbers in this assay, from the lowest: compound 2; then compounds 1 and 3 (each within the scatter of the next).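

In this assay, chloro in place of hydrogen on an aromatic carbon, meta to a trifluoromethyl group, gives a 2.3-fold higher number from compound 2 to compound 3 (0.37 log units; beyond the scatter), a modest shift toward lower toxicity in this test. The earlier change on the amine nitrogen gave a 2.3-fold lower number from compound 1 to compound 2 (0.36 log units; beyond the scatter), so a change of a single heavy atom on the added aromatic ring is enough to produce a step of similar size in the opposite direction. No measured evidence on the compounds accounts for this shift.

The compounds shown leave open whether the upward step is particular to chloro or also appears with fluoro, methoxy or an amine on the same aromatic carbon. Also open, going by these compounds, is whether chloro gives this step without the trifluoromethyl group, as it appears here only together with that group.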